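Chain extension on two nucleoside cores, one step beyond

The source may hold more compounds than are shown below. What is called first, only, known or untested is meant among the compounds shown, and "the series" means these compounds.

Measured in a functional assay on L1210 cells (Mus musculus); on this read-out lower numbers stand for stronger inhibition and higher numbers for weaker inhibition:
Compound 1 `CCCCCCc1cn([C@H]2C[C@@H]3OP(=O)(O)OC[C@H]3O2)c(=O)[nH]c1=O` gives > 500 ug/mL, a limit of the assay.
Compound 2 `CCCCc1cn([C@H]2C[C@H](O)[C@@H](CO)O2)c(=O)[nH]c1=O` gives > 500 ug/mL, a limit of the assay.
Compound 3 `CCCCCc1cn([C@H]2C[C@@H]3OP(=O)(O)OC[C@H]3O2)c(=O)[nH]c1=O` gives > 500 ug/mL, a limit of the assay.

Compound 3 and compound 1 share one core and differ by methyl in place of hydrogen on a saturated chain carbon, five bonds along the chain from an aromatic carbon. The step that the two limits leave unreadable from compound 3 to compound 1 cannot be read, because of the limit of > 500 ug/mL in this assay, at which 3 of the 3 values shown sit. Compound 2 carries a different core; the difference between the two cores is not broken down here. Compound 4 `CCCCCc1cn([C@H]2C[C@H](O)[C@@H](CO)O2)c(=O)[nH]c1=O` stands to compound 2 as compound 1 stands to compound 3, differing by methyl in place of hydrogen on a saturated chain carbon, four bonds along the chain from an aromatic carbon. This is the same kind of change, but here the place is four bonds along the chain from an aromatic carbon rather than five. Going by the values given here, since every value so far is a limit, the step for compound 4 is expected to be small, an estimated step that the limit leaves unreadable from compound 2 to compound 4. Compound 4 is therefore estimated at 700 ug/mL in this assay, most likely reported again only as a limit.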

Compound 4, concentration for 50% inhibition: 477 ug/mL
Compound 4: the middle estimate sits 1.5-fold (0.17 log units) above what was measured; low and high end bracket the measured number.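

In this assay, going by these compounds alone, the one readable step is an at least 1.0-fold lower number from compound 2 to compound 4 (0.02 log units; that floor lies within the scatter), so the added methyl shows at most a floor on the change, not a real size. On the other core, the step from compound 3 to compound 1 cannot be read, because both values are limits: the limit of > 500 ug/mL in this assay, at which 3 of the 4 values shown sit. The two steps therefore cannot be compared, so nothing here shows whether the change carries from one core to the other, and the place also differs, four bonds rather than five bonds along the chain from an aromatic carbon.

The compounds shown leave open whether a longer chain on the core of compound 4 would give a number clearly lower than that of compound 2. They also leave open what an amine in place of the chain would do.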